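The source may hold more compounds than are shown below. What is called first, only, known or untested is meant among the compounds shown, and "the series" means these compounds.

Measured compounds:
compound 1 `COc1cc2c(Oc3ccc(NC(=O)c4nn(-c5ccccc5C)c(=O)cc4C)cc3F)ccnc2cc1OCCCN1CCCC1` — 1300 nM
compound 2 `COc1cc2c(Oc3ccc(NC(=O)c4nn(-c5ccccc5C)c(=O)cc4C)cc3F)ccnc2cc1OCCCN1CCCCC1` — 1920 nM

In a functional assay on A549 cells (Homo sapiens) for inhibition, read by MTT assay, with a stated time of 72 h (a lower number here means a stronger inhibitor, a higher number a weaker inhibitor), compound 2 gives 1920 nM, which lies within the scatter of compound 1, as the step of a 1.5-fold higher number from compound 1 to compound 2 (0.17 log units; within the scatter) shows. Compound 3 `COc1cc2c(Oc3ccc(NC(=O)c4nn(-c5cccc(F)c5)c(=O)cc4C)cc3F)ccnc2cc1OCCCN1CCCCC1` differs from compound 2 by 3-fluorophenyl in place of 2-methylphenyl on an aromatic nitrogen. For the measured compounds named here, no measured step touches this part of the molecule; the single step in hand, a 1.5-fold higher number from compound 1 to compound 2 (0.17 log units; within the scatter), concerns another part and gives no guide, so only a step within the scatter is expected, a 1.0-fold higher number from compound 2 to compound 3 (0.02 log units; within the scatter), with a wide range. Compound 3 is therefore estimated at 2000 nM, between 600 nM and 7000 nM.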

Compound 3, half-maximal inhibitory concentration: 250 nM
Compound 3: middle estimate off by 8.0-fold (0.90 log units), on the high side, and the stated range ends above it.
By their numbers in this assay, from the lowest: compound 3; then compounds 1 and 2 (each within the scatter of the next).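

In this assay, for the compounds shown here, the aromatic nitrogen substituent emerges as a sensitive position: 3-fluorophenyl in place of 2-methylphenyl gives a 7.7-fold lower number from compound 2 to compound 3 (0.89 log units; beyond the scatter) as the only step here to leave the scatter, unlike a 1.5-fold higher number from compound 1 to compound 2 (0.17 log units; within the scatter) at the chain end. Nothing at hand accounts for this step.

As far as these compounds go, the change removes the methyl and adds the fluorine at once, so the contribution of each stays open. Unsubstituted phenyl, 3-methylphenyl or 2-fluorophenyl on that nitrogen would separate them, and pyrrolidin-1-yl paired with 3-fluorophenyl would test whether the two positions act independently.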